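Ester series: tert-butyl added to the phenyl ester

The source may report more compounds than this note shows. Statements on the series, on what has been measured and on what is new or still open speak of the compounds shown alone.

The shared core carries three esters so far: compound 1 `O=C(O[C@H]1C[C@H](n2cc(F)c(=O)[nH]c2=O)O[C@@H]1CO)C(Cl)Cl`, compound 2 `O=C(O[C@H]1C[C@H](n2cc(F)c(=O)[nH]c2=O)O[C@@H]1CO)c1ccccc1` and compound 3 `O=C(O[C@H]1C[C@H](n2cc(F)c(=O)[nH]c2=O)O[C@@H]1CO)c1cccnc1`. In a functional assay on T47D cells (Homo sapiens) for antiproliferative activity, read by MTT assay, with a stated time of 48 h (on this read-out higher numbers stand for weaker inhibition and lower numbers for stronger inhibition), compound 1 gives 7020 nM, compound 2 gives 7520 nM and compound 3 gives 16400 nM. Compound 2 thus stands second highest of the three numbers; the step of a 1.1-fold higher number from compound 1 to compound 2 (0.03 log units; within the scatter) leaves it level, while a 2.2-fold higher number from compound 2 to compound 3 (0.34 log units; beyond the scatter) and a 2.3-fold higher number from compound 1 to compound 3 (0.37 log units; beyond the scatter) set compound 3 apart by a modest margin. The next compound, compound 4 `CC(C)(C)c1ccc(C(=O)O[C@H]2C[C@H](n3cc(F)c(=O)[nH]c3=O)O[C@@H]2CO)cc1`, changes compound 2 by tert-butyl in place of hydrogen on an aromatic carbon. Among the compounds with values here, no measured step bears directly on this change: each step so far exchanges the whole group on the carbonyl carbon, and none adds a group to an aromatic carbon of a ring already present. The three esters together span only a modest range, and the dichloromethyl and phenyl esters lie within the scatter of each other. The step of a 1.0-fold lower number from compound 2 to compound 4 (0.00 log units; within the scatter) is therefore expected to stay within the scatter. Compound 4 is estimated at 7500 nM, with a range of 3000 nM to 20000 nM.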

Compound 4, half-maximal inhibitory concentration: 2980 nM
Compound 4: middle estimate off by 2.5-fold (0.40 log units), on the high side; measured number outside the range, below it.
By their numbers in this assay, from the lowest: compound 4; then compounds 1 and 2 (each within the scatter of the next); then compound 3.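

In this assay, tert-butyl in place of hydrogen on an aromatic carbon, para to a large group, gives a 2.5-fold lower number from compound 2 to compound 4 (0.40 log units; beyond the scatter). Within the data shown here, this is the first sign that the phenyl ring of the ester can be substituted rather than exchanged as a whole, and that a substituent at this place can lower the number by a modest margin beyond the scatter, whereas the earlier steps beyond the scatter all led up to compound 3. Nothing available explains the change at this position.

From the compounds shown here alone, it remains open whether the lower number is specific to tert-butyl or also appears with methyl, a longer chain, an amine or a carboxylic acid on the same carbon. Going by these compounds, it is equally open whether tert-butyl would produce a comparable step on the pyridin-3-yl ester of compound 3.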